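A few compounds are considered here, and "the series" means these few. Any claim that something is new, unique, unknown or untested is made for them only; others in the source may bear on it.

Of the compounds shown here, three have been measured in a physicochemical assay for lipophilicity; a lower number here means a more polar compound, a higher number a more lipophilic compound. Compound 1, with the structure `CC[n+]1ccn(CCN(C)S(=O)(=O)C(F)(F)F)c1/C=N/O`, gives -1.19 in this assay. Compound 2, with the structure `CN(CCCn1cc[n+](C)c1/C=N/O)S(=O)(=O)C(F)(F)F`, gives -1.37 in this assay. Compound 3, with the structure `CC(OCn1cc[n+](C)c1/C=N/O)C(C)(C)[N+](=O)[O-]`, gives -1.75 in this assay, the lowest of the three numbers; its gap to compound 2 and its larger gap to compound 1 both lie beyond the usual scatter, so compound 3 is the most polar of the three measured compounds.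

Compound 4, with the structure `CCS(=O)(=O)CC(C)OCn1cc[n+](C)c1/C=N/O`, has not yet been measured. It differs from compound 3 in one place: (ethylsulfonyl)methyl in place of 1-methyl-1-nitroethyl on a saturated chain carbon bound to an oxygen on a saturated carbon and a saturated chain carbon. The core shared with compound 3 is untouched, and the two groups that swap are of the same size, each with the same count of hydrogen-bond acceptors and no charge. For the measured compounds named here, none of the measured compounds differ from one another in exactly this way, so no measured step exists to set the size of the change directly. On that basis only a small change is expected, if any beyond the scatter, and its direction is taken as slightly downward. For compound 4 the estimated step from compound 3 is a number 0.20 log units lower from compound 3 to compound 4 (within the scatter) in this assay. Compound 4 is therefore expected to give about -1.95 in this assay, within a range from -2.45 to -1.45.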

Compound 4, distribution coefficient: -2.7
Compound 4: the middle estimate sits 0.75 log units above what was measured; measured number below the stated range.
By their numbers in this assay, from the lowest: compound 4; then compound 3; then compounds 2 and 1 (each within the scatter of the next).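

In this assay, putting (ethylsulfonyl)methyl in place of 1-methyl-1-nitroethyl on this saturated chain carbon gives a number 0.95 log units lower from compound 3 to compound 4 (beyond the scatter), so this position is not indifferent to which of the two groups it carries. The two groups have the same count of heavy atoms and of hydrogen-bond acceptors, and neither carries a net charge, so for this pair those matching counts did not hold the number within the scatter; what differs in the counts is sulfur in place of nitrogen, one carbon arrangement, and the number of double bonds. Nothing available explains why the number moved this far.

A single pair cannot show whether the step follows from the loss of the nitro group or from the arrival of the sulfonyl group, and a tert-butyl group or a (methylsulfonyl)methyl group on the same carbon would be needed to separate the two. On these data alone, it also stays open whether the same swap gives a step of similar size on a core carrying an ethyl group in place of the methyl group on the charged nitrogen.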